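Compound 4: acetyl in place of phenoxy

A few compounds are considered here, and "the series" means these few. Any claim that something is new, unique, unknown or untested is made for them only; others in the source may bear on it.

In an ADME assay on Raji cells (Homo sapiens) for cytotoxicity, read by luminescence, with a stated time of 72 h (on this read-out higher numbers stand for an effect only at larger amounts of compound and lower numbers for an effect already at smaller amounts), compound 3 (`CCOC(=O)c1c(-c2cccc(Oc3ccccc3)c2)[nH]c2cc(OC)ccc2c1=O`) gives > 21500 nM as a limit and not a number. Compound 1 (`CCOC(=O)c1c(-c2cccc(C)c2)[nH]c2cc(OC)ccc2c1=O`) gives > 21500 nM as a limit too. Compound 2 (`CCCOc1cccc(-c2[nH]c3cc(OC)ccc3c(=O)c2C(=O)OCC)c1`) likewise gives > 21500 nM as a limit. Compound 3 therefore stands with the rest of the series at the limit of > 21500 nM in this assay, at which 3 of the 3 values shown sit, and has no number of its own.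

The move to compound 4 (`CCOC(=O)c1c(-c2cccc(C(C)=O)c2)[nH]c2cc(OC)ccc2c1=O`) is acetyl in place of phenoxy on an aromatic carbon, with this count: acetyl in place of phenoxy on an aromatic carbon ( the swap is much smaller in heavy atoms ).

Among the measured compounds shown here, three measured steps bear on it: a step that the two limits leave unreadable from compound 1 to compound 3 and a step that the two limits leave unreadable from compound 2 to compound 3 and a step that the two limits leave unreadable from compound 1 to compound 2 ( none gives a size ). Methyl, propoxy and phenoxy all end at the same limit, so no direction can be drawn from them, and compound 4 is expected to stay with that group.

The expected move is a step that the limit leaves unreadable from compound 3 to compound 4 and no real shift is foreseen. The estimate for compound 4 is 25000 nM with an expected range of 10000 nM to 60000 nM and most likely only a limit will be reported.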

Compound 4, half-maximal effective concentration: > 21500 nM
Compound 4: no number, only a limit (the forecaster's own chance of this, stated with the estimate: 85%); the middle value is on the limit's open side.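

The steps to compound 4 from compound 1, compound 2 and compound 3 cannot be read, as compound 4 also gives a limit and not a number: the limit of > 21500 nM in this assay, at which 4 of the 4 values shown sit. The compounds shown leave open whether any group at this place would give a readable half-maximal effective concentration.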